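Chloro to Bromo on the Fused Ring of Compound 1

The source may hold more compounds than are shown below. What is called first, only, known or untested is meant among the compounds shown, and "the series" means these compounds.

Compound 1 `O=C1c2cccc([N+](=O)[O-])c2NC[C@@]12[C@H](c1ccc(Cl)cc1)[C@@H](c1ccccc1)N[C@]21C(=O)Nc2ccc(Cl)cc21`: 18000 nM
Compound 2 `O=C1c2cccc([N+](=O)[O-])c2NC[C@@]12[C@H](c1ccc(Br)cc1)[C@@H](c1ccccc1)N[C@]21C(=O)Nc2ccc(Cl)cc21`: 21000 nM
Compound 3 `COc1ccc([C@@H]2[C@@H](c3ccccc3)N[C@]3(C(=O)Nc4ccc(Cl)cc43)[C@]23CNc2c(cccc2[N+](=O)[O-])C3=O)cc1`: 16000 nM

All three were measured in a functional assay on HeLa cells (Homo sapiens) for cytotoxicity, read by MTT assay, with a stated time of 72 h; a higher number here means a weaker inhibitor, a lower number a stronger inhibitor. Compound 1 holds the second highest of the three numbers, and its gaps to both neighbours lie within the scatter: a 1.2-fold higher number from compound 1 to compound 2 (0.07 log units; within the scatter) and a 1.1-fold lower number from compound 1 to compound 3 (0.05 log units; within the scatter). The remaining measured step, a 1.3-fold lower number from compound 2 to compound 3 (0.12 log units; within the scatter), is also within the scatter, so the three compounds are not separated by this assay.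

Compound 4 `O=C1c2cccc([N+](=O)[O-])c2NC[C@@]12[C@H](c1ccc(Cl)cc1)[C@@H](c1ccccc1)N[C@]21C(=O)Nc2ccc(Br)cc21` differs from compound 1 in one place: bromo in place of chloro on an aromatic carbon. For the measured compounds named here, the only measured swap of the same kind, a 1.2-fold higher number from compound 1 to compound 2 (0.07 log units; within the scatter), produced no shift beyond the scatter. The step to compound 4 is therefore expected to be a 1.1-fold higher number from compound 1 to compound 4 (0.02 log units; within the scatter), with no change beyond the scatter. Compound 4 is expected to give 19000 nM, between 9000 nM and 40000 nM.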

Compound 4, half-maximal inhibitory concentration: 23000 nM
Estimate against measurement, compound 4: 1.2-fold (0.08 log units) below, and the stated range covers the measured number.
By their numbers in this assay, from the lowest: compounds 3, 1, 2 and 4 (each within the scatter of the next).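

The earlier compounds shown here varied only the substituent on the separate aryl ring, while compound 4 changes the chloro on an aromatic carbon within the fused system of five rings. In this assay, this bromo for chloro swap gives a 1.3-fold higher number from compound 1 to compound 4 (0.11 log units; within the scatter), so this position, too, shows no shift beyond the scatter for this change. Nothing shown explains this outcome. The compounds shown carry only chloro or bromo at this position, so whether an amine or a carboxylic acid there would move the number beyond the scatter remains open.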